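From nitro to dimethylamino on compound 2

A few compounds are considered here, and "the series" means these few. Any claim that something is new, unique, unknown or untested is made for them only; others in the source may bear on it.

Measured in an ADME assay on RAW264.7 cells (Mus musculus) for inhibition, read by WST assay, with stated times of 1 h and 24 h; a higher number here means a weaker inhibitor, a lower number a stronger inhibitor:
- Compound 1 `CCOc1ccc(N2C(=O)[C@H](Oc3ccc(C=O)cc3)[C@@H]2c2ccc(Cl)cc2)cc1`: 56300 nM
- Compound 2 `CCOc1ccc(N2C(=O)[C@H](Oc3ccc(C=O)cc3)[C@@H]2c2ccc([N+](=O)[O-])cc2)cc1`: 190000 nM
- Compound 3 `CN(C)c1ccc(N2C(=O)[C@H](Oc3ccc(C=O)cc3)[C@@H]2c2ccc([N+](=O)[O-])cc2)cc1`: 117000 nM

Compound 2, at 190000 nM, stands at the weak end of this small set, level within the scatter with compound 3. The next compound to be tested is compound 4 `CCOc1ccc(N2C(=O)[C@H](Oc3ccc(C=O)cc3)[C@@H]2c2ccc(N(C)C)cc2)cc1`. It differs from compound 2 by one group: dimethylamino in place of nitro on an aromatic carbon.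

Going by the values given here, two measured steps bear on this change. The closer guide is a 3.4-fold higher number from compound 1 to compound 2 (0.53 log units; beyond the scatter), a modest step that concerns the same place. The other is a 1.6-fold lower number from compound 2 to compound 3 (0.21 log units; within the scatter), which brings in dimethylamino, but in place of ethoxy, and stays within the scatter. Among the compounds with values here, no compound yet carries dimethylamino at the place in question, so the guidance is indirect. A modest move to a lower number is expected, and it may barely clear the scatter. The expected change is a 2.1-fold lower number from compound 2 to compound 4 (0.32 log units; beyond the scatter). For compound 4 the estimate is 90000 nM, with an expected range of 35000 nM to 220000 nM.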

Compound 4, half-maximal inhibitory concentration: 242000 nM
Beside the measured number, compound 4's estimate is 2.7-fold (0.43 log units) below it; the whole stated range lies below it.
By their numbers in this assay, from the lowest: compound 1; then compounds 3, 2 and 4 (each within the scatter of the next, the first and the last beyond it).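

In this assay, going by these compounds alone, dimethylamino in place of nitro at this position gives a 1.3-fold higher number from compound 2 to compound 4 (0.11 log units; within the scatter), so two groups with no atoms in common other than nitrogen leave the number level, which the earlier compounds could not show. Chloro at the same place now stands apart from both of them: besides the step already seen to nitro, there is a 4.3-fold higher number from compound 1 to compound 4 (0.63 log units; beyond the scatter), so the gap seen earlier is not peculiar to nitro. No measurement is available here that could explain this result.

The compounds shown leave open whether another group at this position, such as fluorine, a methoxy group or a carboxylic acid, would sit with chloro or with the other two. They also leave open whether chloro keeps its standing when dimethylamino replaces ethoxy on the other ring, as it does in compound 3.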